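The source may hold more compounds than are shown below. What is called first, only, known or untested is meant among the compounds shown, and "the series" means these compounds.

In a toxicity assay on NIH3T3 cells (Mus musculus) for cytotoxicity, read by resazurin assay (a higher number here means that more compound is needed for the effect, a lower number that less compound is needed), three compounds sharing one core have been read so far, and none has given a number. Compound 1 `Clc1ccc(NCc2cncn2Cc2ccc(-c3ccccc3)cc2)cc1-c1ccccc1` gives > 1000 nM, which is a limit of the assay. Compound 2 `c1ccc(-c2ccc(Cn3cncc3CNc3ccc(-c4nc5ccccc5s4)c(-c4ccccc4)c3)cc2)cc1` gives > 1000 nM, again a limit. Compound 3 `c1ccc(-c2ccc(Cn3cncc3CNc3ccc(-c4nc5ccccc5o4)c(-c4ccccc4)c3)cc2)cc1` gives > 10000 nM, also a limit, so its place on the scale is not fixed by a number.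

Compound 4 `c1ccc(-c2ccc(Cn3cncc3CNc3ccc(N4CCCC4)c(-c4ccccc4)c3)cc2)cc1` carries pyrrolidin-1-yl in place of 1,3-benzoxazol-2-yl on an aromatic carbon. Going by the values given here, three measured steps bear on this change, all of them swaps of the group on that same carbon. They are a step that the two limits leave unreadable from compound 1 to compound 2, a step that the two limits leave unreadable from compound 1 to compound 3 and a step that the two limits leave unreadable from compound 2 to compound 3, and none has a readable size. No measured size or direction therefore carries over to this assay. Resting on compound 3 and its limit of > 10000 nM, the expectation is of no step beyond the scatter, and the expected step is a number no higher from compound 3 to compound 4 (the limit leaves the size open). Compound 4 is estimated at 10000 nM, with an expected range from 3000 nM to 30000 nM.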

Compound 4, half-maximal effective concentration: > 1000 nM
Compound 4: no number, only a limit (the forecaster's own chance of this, stated with the estimate: 75%); the middle value is on the limit's open side.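

In this assay, going by these compounds alone, compound 4 gives > 1000 nM, which is a limit, so no step between it and compound 1, compound 2 or compound 3 can be read. The compounds shown leave open where any of the four sits on the scale, and whether swapping the group on that aromatic carbon changes the value at all.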